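Series notes: aryl swap from compound 3 to compound 4

This account rests on a few compounds, and the source may have more. Where it says the series, first, only, none or still open, it means among the compounds named here.

Measured so far in an in vitro assay on HEK385-7 cells for displacement of a labelled ligand from prostaglandin D2 receptor 2 (Homo sapiens); a higher number here means a weaker inhibitor, a lower number a stronger inhibitor:
compound 1, `O=C(O)Cc1sc(C(c2ccccc2)c2ccccc2)nc1-c1ccc(F)cc1`, gives 8.7 nM
compound 2, `O=C(O)Cc1sc(C(c2ccccc2)c2ccc(O)cc2)nc1-c1ccc(F)cc1`, gives 3.4 nM
compound 3, `O=C(O)Cc1sc(C(c2ccc(F)cc2)c2ccc(F)cc2)nc1-c1cccc(F)c1`, gives 1.4 nM

Compound 3 holds the lowest number of the three. Compound 2 stands nearest to it with a higher number, and compound 1 stands furthest, again with a higher number; both gaps are beyond the scatter. Compound 3 is thus the strongest inhibitor measured here.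

For the measured compounds named here, the only single-point step recorded is a 2.6-fold lower number from compound 1 to compound 2 (0.41 log units; beyond the scatter), which concerns the diphenylmethyl part and not the aromatic group on the five-membered core.

Compound 4, `O=C(O)Cc1sc(C(c2ccc(F)cc2)c2ccc(F)cc2)nc1-c1ccnc(F)c1`, differs from compound 3 in one place: 2-fluoropyridin-4-yl in place of 3-fluorophenyl on an aromatic carbon. Going by the values given here, no measured pair changes this group alone, so nothing recorded bears directly on the step. Compound 1 and compound 3 differ in this group and elsewhere, so their two values cannot be split by position. With no guide, the expected step of a 1.1-fold higher number from compound 3 to compound 4 (0.06 log units; within the scatter) in this assay is none beyond the scatter. Compound 4 is therefore estimated at 1.6 nM, with a range from 0.5 nM to 5 nM.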

Compound 4, half-maximal inhibitory concentration: 0.48 nM
Compound 4: the middle estimate sits 3.3-fold (0.52 log units) above what was measured; measured number below the stated range.
By their numbers in this assay, from the lowest: compound 4; then compound 3; then compound 2; then compound 1.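

Notes on the aryl position: in this assay the change to 2-fluoropyridin-4-yl from 3-fluorophenyl gives a 2.9-fold lower number from compound 3 to compound 4 (0.46 log units; beyond the scatter) and is the first step in the series read at this position alone, on the aromatic carbon next to the ring nitrogen. The position therefore responds to a change within the aromatic group itself: the count of heavy atoms stays the same, a ring carbon gives way to nitrogen, and the entering group carries a hydrogen-bond acceptor where the leaving group carries none. No measurement at hand accounts for the size or direction of this step.

The compounds shown do not separate the contribution of the ring nitrogen from that of the fluorine, since none carries an unsubstituted pyridin-4-yl group or a pyridine ring with methoxy or an amine in place of the fluorine. On these data alone, it also remains open whether the same swap would give a similar step with the unsubstituted diphenylmethyl group of compound 1 or the hydroxy-bearing group of compound 2.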